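Working notes: cytotoxicity across three related compounds

The source may hold more compounds than are shown below. What is called first, only, known or untested is meant among the compounds shown, and "the series" means these compounds.

compound 1 `CC(O)c1ccc(C(=O)N[C@@H](C)Cn2ccc(-c3ccc(C#N)c(Cl)c3)n2)cc1`: > 30000 nM
compound 2 `COC(=O)/C=C/C(=O)N[C@@H](C)Cn1ccc(-c2ccc(C#N)c(Cl)c2)n1`: "not determined" (no result reported)

In an ADME assay on L02 cells (Homo sapiens) for cytotoxicity, read by CCK-8 assay, with a stated time of 6 days (on this read-out lower numbers stand for stronger inhibition and higher numbers for weaker inhibition), compound 1 gives > 30000 nM, which is a limit of the assay and not a number. Compound 2 has no result in this assay; its entry reads "not determined" (no result reported). Compound 2 therefore stands nowhere on the numbers shown, and the only value in this assay is the limit of compound 1 (the limit of > 30000 nM in this assay, at which 1 of the 2 values shown sits). Compound 3 `Cc1ccnc(N[C@@H](C)Cn2ccc(-c3ccc(C#N)c(Cl)c3)n2)n1` differs from compound 2 by 4-methylpyrimidin-2-yl in place of (2-(methoxycarbonyl)ethenyl)carbonyl on an amine nitrogen. Among the measured compounds shown here, no measured step joins any two compounds here, so the size of any shift from compound 2 to compound 3 in this assay cannot be read from the data; the single anchor is compound 1 at the limit of > 30000 nM in this assay, at which 1 of the 2 values shown sits, which suggests weak cytotoxicity in this set and makes a further limit the most likely outcome for compound 3. Compound 3 is expected to give about 30000 nM in this assay, with a range from 12000 nM to 60000 nM.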

Compound 3, half-maximal inhibitory concentration: > 30000 nM
Compound 3 gave a limit, no number; the forecaster's own chance of this, stated with the estimate: 70%; the middle value lies on the limit itself.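

No new step can be read for compound 2 or compound 3: compound 2 carries no number in this assay, and compound 3 gives only a limit, not a number. The compounds shown leave open where any of them would give a number, given the shared limit: the limit of > 30000 nM in this assay, at which 2 of the 3 values shown sit.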